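This account rests on a few compounds, and the source may have more. Where it says the series, first, only, none or still open, it means among the compounds named here.

Values in an ADME assay on HEK293 cells (Homo sapiens) for cytotoxicity, read by MTT assay, with a stated time of 48 h; on this read-out lower numbers stand for stronger inhibition and higher numbers for weaker inhibition:
Compound 1 `Cn1c(N)c(-c2nc3ccccc3[nH]2)c2nc(C#N)c(C#N)nc21`: > 50000 nM
Compound 2 `CCN(CC)CCCCn1c(N)c(-c2nc3cc(Cl)ccc3[nH]2)c2nc(C#N)c(C#N)nc21`: 3860 nM
Compound 3 `CN(C)CCCCn1c(-c2c(N)n(C)c3nc(C#N)c(C#N)nc23)nc2ccccc21`: 7130 nM

The entry for compound 1, > 50000 nM, is a limit of the assay and not a number. Of the two true numbers, compound 3 gives 7130 nM and compound 2 gives 3860 nM, and these lie within the usual scatter of each other. Among the measured compounds shown here, the one measured step reaching compound 3 is an at least 7.0-fold lower number from compound 1 to compound 3 (0.84 log units; beyond the scatter). It puts 4-(dimethylamino)butyl in place of hydrogen on an aromatic nitrogen, and it starts from the limit of > 50000 nM in this assay, at which 1 of the 3 values shown sits.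

Compound 4 `CCN(CC)CCCCn1c(-c2c(N)n(C)c3nc(C#N)c(C#N)nc23)nc2ccccc21` alters only the end of that chain: diethylamino in place of dimethylamino on a saturated chain carbon, four bonds along the chain from an aromatic nitrogen. For the measured compounds named here, no measured step isolates this exchange, and the step to compound 3 concerns the whole chain, so it sets no size for it. Going by the values given here, the only other guide is compound 2, which also carries diethylamino and gives 3860 nM. A small move toward lower numbers in this assay, or none beyond the scatter, is therefore expected. The expected step is a 1.6-fold lower number from compound 3 to compound 4 (0.20 log units; within the scatter). Compound 4 is estimated at 4500 nM, with an expected range from 1800 nM to 11000 nM.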

Compound 4, half-maximal inhibitory concentration: 8820 nM
Compound 4: middle estimate off by 2.0-fold (0.29 log units), on the low side; the range from low to high includes it.
By their numbers in this assay, from the lowest: compounds 2, 3 and 4 (each within the scatter of the next, the first and the last beyond it). At a limit, above all of these: compound 1.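

In this assay, diethylamino in place of dimethylamino on a saturated chain carbon, four bonds along the chain from an aromatic nitrogen, gives a 1.2-fold higher number from compound 3 to compound 4 (0.09 log units; within the scatter) and so does not separate the two end groups at this position. The whole chain shows the larger change: the butyl chain ending in diethylamino gives an at least 5.6-fold lower number from compound 1 to compound 4 (0.75 log units; beyond the scatter) and the butyl chain ending in dimethylamino gives an at least 7.0-fold lower number from compound 1 to compound 3 (0.84 log units; beyond the scatter), so among compounds 1, 3 and 4 the lower numbers go with the chain, whichever of these two amines ends it. Compound 1 stands at a limit and not at a number, so both steps from it give only a bound on their size: the limit of > 50000 nM in this assay, at which 1 of the 4 values shown sits.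

The compounds shown leave open how a cyclic amine such as pyrrolidine or morpholine at the end of the chain, or a shorter or longer chain than butyl, would fall in this assay. They also leave the chlorine of compound 2 unresolved, since compound 2 differs from compound 4 in more than one place.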